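Benzyl for 4-fluorophenyl on the fused core

This account rests on a few compounds, and the source may have more. Where it says the series, first, only, none or still open, it means among the compounds named here.

Measured so far in a functional assay on L1210 cells (Mus musculus) for inhibition, read by cell counting, with a stated time of 2 days; on this read-out higher numbers stand for weaker inhibition and lower numbers for stronger inhibition:
compound 1 `CCc1ccc(-c2nn3cc(-c4cccc(N)c4)nc3s2)cc1` gives 6000 nM
compound 2 `C=C(Br)C(=O)Nc1cccc(-c2cn3nc(-c4ccc(F)cc4)sc3n2)c1` gives 250 nM

Compound 2 holds the lowest of the two numbers in this assay; compound 1 gives a higher number, and the gap between them lies beyond the scatter. For the measured compounds named here, the two differ in more than one place, so no single step between them can be read, and their values are taken only as they stand.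

Compound 3 `C=C(Br)C(=O)Nc1cccc(-c2cn3nc(Cc4ccccc4)sc3n2)c1` is the next compound for this assay. It keeps the bromoacrylamide-bearing aniline and the shared core of compound 2 and changes one site: benzyl in place of 4-fluorophenyl on an aromatic carbon. The leaving and entering groups match in heavy-atom count and in the absence of donors and acceptors; the change is the loss of the fluorine and the insertion of a methylene between the ring and the core.

With no measured step of this kind in the series, a small shift is expected, more likely toward a higher number than a lower one, and possibly within the scatter. The expected step from compound 2 to compound 3 is a 2.4-fold higher number from compound 2 to compound 3 (0.38 log units; beyond the scatter). Compound 3 is expected to give about 600 nM, between 150 nM and 2500 nM.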

Compound 3, half-maximal inhibitory concentration: 3000 nM
For compound 3 the middle estimate is 5.0-fold (0.70 log units) below the measured one; the whole stated range lies below it.
By their numbers in this assay, from the lowest: compound 2; then compounds 3 and 1 (each within the scatter of the next).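

For the compounds shown here, this is the first step that can be read: in this assay, benzyl in place of 4-fluorophenyl on an aromatic carbon of the five-membered aromatic ring gives a 12-fold higher number from compound 2 to compound 3 (1.08 log units; beyond the scatter). The position is therefore sensitive to what it carries, since the bromoacrylamide-bearing aniline and the shared core stay the same and the two groups match in heavy-atom count and in hydrogen-bond donors and acceptors, yet the read-out still moves by a large step. Nothing measured in the series accounts for this step.

Going by these compounds alone, the single step joins the loss of the fluorine and the insertion of the methylene, and a plain phenyl or a 4-fluorobenzyl group on this carbon would be needed to tell the two apart. Also open, as far as these compounds go, is how the position responds to other kinds of group, such as an amine, a carboxylic acid or a longer chain like 2-phenylethyl, while steps to compound 1 cannot be read, as it differs from both other compounds in more than one place.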